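Amide-linked variants of a shared core: cytotoxicity notes

The source may report more compounds than this note shows. Statements on the series, on what has been measured and on what is new or still open speak of the compounds shown alone.

Measured so far:
Compound 1 `Cn1c(-c2ccc(NC(=O)CCl)cc2)nc(-c2ccccc2)c1-c1ccccc1` gives 14.4% in a functional assay on HT-29 cells (Homo sapiens) for cytotoxicity, read by MTT assay, with a stated time of 24 h, tested at 1.6 ug/mL; on this read-out higher numbers stand for a stronger effect at the one concentration tested and lower numbers for a weaker effect.
Compound 2 `Cc1ccc2oc(SCC(=O)Nc3ccc(-c4nc(-c5ccccc5)c(-c5ccccc5)n4C)cc3)nc2c1` gives 15.5% in this assay.
Compound 3 `Cn1ccnc1SCC(=O)Nc1ccc(-c2nc(-c3ccccc3)c(-c3ccccc3)n2C)cc1` gives 23.8% in this assay.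

Compound 2 stands second highest of the three numbers as they stand: its nearest is compound 1, with a number 1.1 percentage points higher from compound 1 to compound 2 (within the scatter), its furthest is compound 3, with a number 8.3 percentage points higher from compound 2 to compound 3 (within the scatter). Compound 4 `CN1CCN(CC(=O)Nc2ccc(-c3nc(-c4ccccc4)c(-c4ccccc4)n3C)cc2)CC1` is not yet measured; it differs from compound 2 by 4-methylpiperazin-1-yl in place of (5-methyl-1,3-benzoxazol-2-yl)sulfanyl on a saturated chain carbon bound to a carbonyl carbon. Among the measured compounds shown here, the steps that bear on this change are those at the same saturated chain carbon: a number 1.1 percentage points higher from compound 1 to compound 2 (within the scatter), a number 9.4 percentage points higher from compound 1 to compound 3 (within the scatter) and a number 8.3 percentage points higher from compound 2 to compound 3 (within the scatter), none of them beyond the scatter. No step beyond the scatter is therefore expected for compound 4, a number 1.5 percentage points higher from compound 2 to compound 4 (within the scatter). Compound 4 is estimated at 17%, between 6% and 30%.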

Compound 4, a percentage reported as activity, at one concentration (the size of the read-out at that concentration, not a potency): 27.4%
The estimate for compound 4 lay 10.4 percentage points below the measured number, within the range that was stated.
By their numbers in this assay, from the lowest: compounds 1, 2, 3 and 4 (each within the scatter of the next, the first and the last beyond it).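

Among the compounds shown here, at the saturated chain carbon bound to a carbonyl carbon, 4-methylpiperazin-1-yl gives the first steps beyond the scatter in this assay: a number 11.9 percentage points higher from compound 2 to compound 4 (beyond the scatter) and a number 13 percentage points higher from compound 1 to compound 4 (beyond the scatter), both modest. The same change reads differently against (1-methyl-1H-imidazol-2-yl)sulfanyl, with a number 3.6 percentage points higher from compound 3 to compound 4 (within the scatter), so its size depends on the group that leaves. No measurement at hand accounts for these steps.

Still open, on these data alone, is whether morpholin-4-yl or an open-chain dimethylamino group on this carbon matches 4-methylpiperazin-1-yl. Also open, as far as these compounds go, is how a longer chain carrying 4-methylpiperazin-1-yl would read.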